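The source may hold more compounds than are shown below. What is called first, only, known or untested is meant among the compounds shown, and "the series" means these compounds.

Measured in a functional assay on Bel-7402 cells (Homo sapiens) for cytotoxicity, read by MTT assay; a lower number here means a stronger inhibitor, a higher number a weaker inhibitor:
- compound 1 `CCn1cc(C(=O)Nc2cccc([N+](=O)[O-])c2)c(=O)c2cc(F)c(N3CCNC(C)C3)c(F)c21`: 1000 nM
- compound 2 `CCn1cc(C(=O)Nc2ccc(C)c([N+](=O)[O-])c2)c(=O)c2cc(F)c(N3CCNC(C)C3)c(F)c21`: 29100 nM
- compound 3 `CCn1cc(C(=O)NCc2ccc(OC)cc2)c(=O)c2cc(F)c(N3CCNC(C)C3)c(F)c21`: 10300 nM

Of these three numbers, compound 3 at 10300 nM holds the second highest place. The next compound, compound 4 `CCn1cc(C(=O)Nc2ccc(OC(F)(F)F)cc2)c(=O)c2cc(F)c(N3CCNC(C)C3)c(F)c21`, keeps the shared core and differs at one place: 4-(trifluoromethoxy)phenyl in place of 4-methoxybenzyl on an amide-type nitrogen. Put simply, 4-(trifluoromethoxy)phenyl stands in place of 4-methoxybenzyl on an amide-type nitrogen.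

Two measured steps make the same kind of exchange at that nitrogen, and they point in opposite directions: a 10-fold higher number from compound 1 to compound 3 (1.01 log units; beyond the scatter), and a 2.8-fold lower number from compound 2 to compound 3 (0.45 log units; beyond the scatter). Going from a benzyl group to a phenyl group therefore has no settled direction in these data. The phenyl amides also differ widely among themselves, as shown by a 29-fold higher number from compound 1 to compound 2 (1.46 log units; beyond the scatter). Among the compounds with values here, no measured compound carries a trifluoromethoxy group, so the size of its contribution is unknown.

With the two phenyl amides lying on either side of compound 3, no step beyond the scatter is firmly expected, though the range must stay wide. The expected step is a 1.5-fold lower number from compound 3 to compound 4 (0.17 log units; within the scatter). For compound 4 the estimated value is 7000 nM, with an expected range from 1200 nM to 30000 nM.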

Compound 4, half-maximal inhibitory concentration: 2000 nM
Compound 4: the middle estimate sits 3.5-fold (0.54 log units) above what was measured; measured number inside the range.
By their numbers in this assay, from the lowest: compounds 1 and 4 (each within the scatter of the next); then compound 3; then compound 2.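

In this assay the exchange of 4-methoxybenzyl for 4-(trifluoromethoxy)phenyl on the amide-type nitrogen gives a 5.2-fold lower number from compound 3 to compound 4 (0.71 log units; beyond the scatter) and so places a second phenyl amide on the lower side of the benzyl amide, with compound 2 the one phenyl amide that goes against this. The wide spread among the phenyl amides now looks different, since the result is a 15-fold lower number from compound 2 to compound 4 (1.16 log units; beyond the scatter) and also a 2.0-fold higher number from compound 1 to compound 4 (0.30 log units; within the scatter) and so compound 1 and compound 4 cannot be told apart, although their phenyl rings carry different groups, while compound 2 stands apart from both. No measurement is available that would explain these differences.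

The step from compound 3 to compound 4 changes benzyl to phenyl and methoxy to trifluoromethoxy at once, so the compounds shown do not separate the two exchanges, and only one benzyl amide is available to compare. On these data alone, an unsubstituted phenyl, a 4-methoxyphenyl or a 4-(trifluoromethoxy)benzyl on this nitrogen would be needed to tell how much each exchange contributes, and whether the methyl group of compound 2 has the same effect on other phenyl amides also remains open.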